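This account rests on a few compounds, and the source may have more. Where it says the series, first, only, none or still open, it means among the compounds named here.

Measured compounds:
Compound 1 `O=C(Nc1nc2ccc(Oc3ccc(F)c(NC(=O)C4(c5cccc(C(F)(F)F)c5)CC4)c3)cc2s1)C1CC1`: "not determined" (no result reported)
Compound 2 `O=C(Nc1cccc(Br)c1)Nc1cc(Oc2ccc3nc(NC(=O)C4CC4)sc3c2)ccc1F`: 81 nM
Compound 3 `O=C(Nc1nc2ccc(Oc3ccc(F)c(NS(=O)(=O)c4cccc(C(F)(F)F)c4)c3)cc2s1)C1CC1`: "not determined" (no result reported)

Three compounds built on the same shared core were entered into an assay for binding affinity to receptor-interacting serine/threonine-protein kinase 3 (Homo sapiens), read by KINOMEscan and polymerase chain reaction, with a stated time of 1 h; on this read-out lower numbers stand for tighter binding and higher numbers for weaker binding. Only compound 2 came back with a number; for compound 1 and compound 3 no result was reported, so nothing can be said about how they compare. Compound 2 therefore stands alone as the single reference point, and in this assay compound 2 gives 81 nM.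

The next compound, compound 4 `CC(=O)c1cccc(NC(=O)Nc2cc(Oc3ccc4nc(NC(=O)C5CC5)sc4c3)ccc2F)c1`, has not yet been measured. It differs from compound 2 in one place: acetyl in place of bromo on an aromatic carbon. Put simply, the (3-bromophenyl)carbamoyl end of compound 2 becomes a (3-acetylphenyl)carbamoyl end in compound 4, and everything else is kept.

Going by the values given here, no pair of measured compounds here shows the effect of a single change of this kind, so there is no measured step to lean on. With one small group swapped for another small group at the far end of the molecule, the expectation is that the step from compound 2 to compound 4 stays modest and lies close to the usual scatter, perhaps leaning slightly toward weaker binding; that expected step is a 1.5-fold higher number from compound 2 to compound 4 (0.17 log units; within the scatter). Resting on compound 2 at 81 nM, compound 4 is estimated at 120 nM, with a plausible range from 40 nM to 400 nM.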

Compound 4, dissociation constant: 53 nM
Estimate against measurement, compound 4: 2.3-fold (0.35 log units) above; the measured number falls inside the stated range.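

In this assay, putting acetyl in place of bromo on this aromatic carbon gives a 1.5-fold lower number from compound 2 to compound 4 (0.18 log units; within the scatter), and this is the only measured single change among the compounds shown. The step shows that this position, meta to a large group, can carry either a single bromine or an acetyl group of 3 heavy atoms, with a double bond outside the ring and a hydrogen-bond acceptor, and the two compounds cannot be told apart on this read-out. Nothing shown here offers an explanation for this result, so it stands as an observation about one pair and says nothing about why the two groups read alike.

As far as these compounds go, a single pair cannot show how far this freedom extends, so it remains open whether an amine, a carboxylic acid or a longer chain such as propanoyl on the same aromatic carbon would also stay within the scatter of these two compounds. From the compounds shown here alone, it is equally open whether acetyl or bromo would read the same way on a different carbon of this ring, or with any other part of the shared core changed.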